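The source may hold more compounds than are shown below. What is called first, only, known or untested is meant among the compounds shown, and "the series" means these compounds.

compound 1 `Cc1cc(Cl)ccc1Nc1nc(C(F)(F)F)ccc1C(=O)N/N=C/c1ccc(N(C)C)cc1`: 66100 nM
compound 2 `Cc1cc(Cl)ccc1Nc1nc(C(F)(F)F)ccc1C(=O)N/N=C/c1ccc(Cl)cc1`: 7590 nM
compound 3 `Cc1cc(Cl)ccc1Nc1nc(C(F)(F)F)ccc1C(=O)N/N=C/c1c(Cl)cccc1Cl`: 11700 nM

In a functional assay on NCI60 cells (Homo sapiens) for cytotoxicity, read by sulforhodamine B assay, with a stated time of 48 h (on this read-out lower numbers stand for stronger inhibition of growth and higher numbers for weaker inhibition of growth), compound 3 stands second highest of the three numbers: the gap a 1.5-fold higher number from compound 2 to compound 3 (0.19 log units; within the scatter) is within the scatter, whereas a 5.6-fold lower number from compound 1 to compound 3 (0.75 log units; beyond the scatter) lies beyond it. Compound 4 `Cc1ccc(Cl)cc1Nc1nc(C(F)(F)F)ccc1C(=O)N/N=C/c1c(Cl)cccc1Cl` is not yet measured. It differs from compound 3 by 5-chloro-2-methylphenyl in place of 4-chloro-2-methylphenyl on a nitrogen on an aromatic ring; the two have the same atoms, joined differently. For the measured compounds named here, none of the measured steps touches this part of the shared core: an 8.7-fold lower number from compound 1 to compound 2 (0.94 log units; beyond the scatter) and a 5.6-fold lower number from compound 1 to compound 3 (0.75 log units; beyond the scatter) both alter the aryl on the carbon with a double bond to nitrogen, and the group on the nitrogen on the aromatic ring is 4-chloro-2-methylphenyl in every measured compound. There is thus no direct guide to the size of this step in this assay. Going by the values given here, the only comparison of two chlorinated aryls differing in substitution pattern, a 1.5-fold higher number from compound 2 to compound 3 (0.19 log units; within the scatter), stayed within the scatter, but it concerns a different position of the molecule and carries limited weight here. Expected for compound 4 is a step of a 1.0-fold higher number from compound 3 to compound 4 (0.01 log units; within the scatter), that is no change beyond the scatter, with wide uncertainty in either direction. The estimate for compound 4 in this assay is 12000 nM, between 4000 nM and 36000 nM.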

Compound 4, concentration for total growth inhibition: 6170 nM
Estimate against measurement, compound 4: 1.9-fold (0.29 log units) above; the measured number falls inside the stated range.
By their numbers in this assay, from the lowest: compounds 4, 2 and 3 (each within the scatter of the next); then compound 1.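

In this assay, for the compounds shown here, the step of a 1.9-fold lower number from compound 3 to compound 4 (0.28 log units; within the scatter) gives the first reading on the aryl on the nitrogen on an aromatic ring, since all earlier steps changed only the aryl on the carbon with a double bond to nitrogen. Exchanging 4-chloro-2-methylphenyl for 5-chloro-2-methylphenyl, with atom content unchanged, leaves the two numbers within the scatter, so this assay does not separate these two isomeric aryls when 2,6-dichlorophenyl is held constant. No measurement on hand explains the size of this step or links it to any property of either aryl.

Going by these compounds alone, this single pair leaves open whether the same exchange would also stay within the scatter with 4-chlorophenyl or 4-(dimethylamino)phenyl on the carbon with a double bond to nitrogen, where the earlier steps were larger. It also leaves open how far the aryl on the nitrogen tolerates a real change of group, such as a methoxy or a carboxylic acid in place of the chlorine, or an ethyl in place of the methyl.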